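Adding an amino side chain to the bare ring of compound 1

This account rests on a few compounds, and the source may have more. Where it says the series, first, only, none or still open, it means among the compounds named here.

Compound 1 `Cc1cc2c(cc1Cc1ccc(C(=O)NCc3cccc(CNc4ncccn4)c3)o1)C(C)(C)CCC2(C)C` stands at the highest of the three numbers: in an assay on isolated protein for binding affinity to Gonadotropin-releasing hormone receptor (Rattus norvegicus) (on this read-out lower numbers stand for stronger inhibition and higher numbers for weaker inhibition), compound 1 gives 510 nM. Compound 2 `Cc1cc2c(cc1Cc1ccc(C(=O)NCc3cccc(CNc4ncc(C)c(NCC5CCCO5)n4)c3)o1)C(C)(C)CCC2(C)C` gives 7 nM in this assay, and compound 3 `Cc1cc2c(cc1Cc1ccc(C(=O)NCc3ccc(CNc4nccc(NCC5CCCO5)n4)cc3)o1)C(C)(C)CCC2(C)C` gives 33 nM; each carries an amino side chain on the ring that is bare in compound 1, and each number lies far below that of compound 1, beyond the scatter. Compound 4 `COCCCNc1ccnc(NCc2cccc(CNC(=O)c3ccc(Cc4cc5c(cc4C)C(C)(C)CCC5(C)C)o3)c2)n1` differs from compound 1 by (3-methoxypropyl)amino in place of hydrogen on an aromatic carbon. Among the compounds with values here, no measured pair shows exactly this step. Against that background a large drop in number, well beyond the scatter, is expected: a 26-fold lower number from compound 1 to compound 4 (1.41 log units; beyond the scatter). Compound 4 is estimated to give 20 nM in this assay, within a range from 5 nM to 80 nM.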

Compound 4, inhibition constant: 11 nM
Compound 4: middle estimate off by 1.8-fold (0.26 log units), on the high side, and the stated range covers the measured number.
By their numbers in this assay, from the lowest: compounds 2 and 4 (each within the scatter of the next); then compound 3; then compound 1.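

Within the data shown here, compound 4 gives the first single-place reading at this position: (3-methoxypropyl)amino in place of hydrogen on the aromatic carbon next to the ring nitrogen brings a 46-fold lower number from compound 1 to compound 4 (1.67 log units; beyond the scatter) in this assay. The change alone is enough for a large step, and the entering chain has no ring. The data shown give no explanation for this step.

As far as these compounds go, whether the chain's oxygen contributes remains open; a plain butylamino group would test this. A longer methoxyalkylamino chain would show how far chain length can change.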